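The compounds below may be only part of what the source reports. "The series", "measured", "known", "first", "only" and "open" are said of these compounds alone.

Measured compounds:
compound 1 `Cc1nn([C@H](C)c2ccc(Cl)cc2Cl)c2nc(N3CC[C@H](N4CCC[C@H]4CCS(C)(=O)=O)[C@H](C)C3)cnc12`, result in an assay on CCRF-CEM cells for antagonist activity at C-C chemokine receptor type 4 (Homo sapiens), read by CellTiter-Glo, with stated times of 30 min and 60 min, in the presence of a further agent that is not named here; a higher number here means a weaker inhibitor, a lower number a stronger inhibitor: "not determined" (no result reported)
compound 2 `C[C@@H]1CC(c2cnc3c(C#N)nn([C@H](C)c4ccc(Cl)cc4Cl)c3n2)=CC[C@@H]1N1CCC[C@H]1C`, result in this assay: 44 nM

Compound 1 stands without a number in this assay; no result was reported for it, so it cannot be placed against compound 2. Within the data shown here, compound 2, built on a different core, is the only point with a value, and in this assay compound 2 gives 44 nM. Compound 3 `Cc1nn([C@H](C)c2ccc(Cl)cc2Cl)c2nc(N3CC[C@H](N4CCC[C@H]4CO)[C@H](C)C3)cnc12` is the unmeasured compound. It differs from compound 1 in one place: hydroxy in place of (methylsulfonyl)methyl on a saturated chain carbon bound to a saturated ring carbon. Among the measured compounds shown here, with no number for compound 1, no step in this assay can be anchored; the change is expected to be modest, in either direction, likely not far beyond the scatter. Compound 3 is therefore estimated at 60 nM, within 12 nM to 300 nM.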

Compound 3, half-maximal inhibitory concentration: 151 nM
Estimate against measurement, compound 3: 2.5-fold (0.40 log units) below; low and high end bracket the measured number.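

Among these compounds, compound 1 carries no number in this assay, so no step from it to compound 3 can be read. The compounds shown leave open how hydroxy in place of (methylsulfonyl)methyl alters inhibition. No other data shown bear on this result.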